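The source may report more compounds than this note shows. Statements on the series, on what has been measured and on what is new or still open speak of the compounds shown alone.

Working notes on a small series built on one shared core. Compound 3 `ClCc1cccc(Cn2cnc3nc(Cl)nc(Cl)c32)c1` and compound 1 `ClCc1cccc(Cn2cnc3ncnc(Cl)c32)c1` differ by hydrogen in place of chloro on an aromatic carbon. In a functional assay on OVCAR-3 cells (Homo sapiens) for cytotoxicity, read by sulforhodamine B assay, with a stated time of 48 h (on this read-out lower numbers stand for stronger inhibition of growth and higher numbers for weaker inhibition of growth), compound 3 gives 2880 nM and compound 1 gives 3230 nM, a step of a 1.1-fold higher number from compound 3 to compound 1 (0.05 log units; within the scatter). Compound 2 `ClCc1ccc(Cn2cnc3nc(Cl)nc(Cl)c32)cc1` has the same atoms as compound 3 joined differently; the difference between the two cores is not broken down here. In this assay compound 2 gives 720 nM, the lowest of the three measured numbers, with both other compounds lying beyond the scatter. Compound 4 `ClCc1ccc(Cn2cnc3ncnc(Cl)c32)cc1` is not yet measured. It differs from compound 2 by hydrogen in place of chloro on an aromatic carbon, the same change as from compound 3 to compound 1, described at the same place in the same words. Because that earlier step was a 1.1-fold higher number from compound 3 to compound 1 (0.05 log units; within the scatter), the step from compound 2 to compound 4 is expected to be about a 1.1-fold higher number from compound 2 to compound 4 (0.05 log units; within the scatter). Compound 4 is accordingly estimated at 800 nM, expected to fall between 400 nM and 1800 nM.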

Compound 4, concentration for total growth inhibition: 3380 nM
For compound 4 the middle estimate is 4.2-fold (0.63 log units) below the measured one; the measured number lies above the stated range.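

Hydrogen in place of chloro on an aromatic carbon gives a 4.7-fold higher number from compound 2 to compound 4 (0.67 log units; beyond the scatter) in this assay and so does not carry over unchanged between these two cores, which join the same atoms differently: the same change on two cores in this assay, a 1.1-fold higher number (0.05 log units; within the scatter) from compound 3 to compound 1 and a 4.7-fold higher number (0.67 log units; beyond the scatter) from compound 2 to compound 4, 4.2-fold (0.62 log units) apart, beyond the scatter of two such steps. The two pairs show that a step read on one core cannot be assumed on the other in this series. They do not show which structural difference between the cores matters, and two pairs set no general rule.

From the compounds shown here alone, it remains open whether an amine or a methoxy group at the same ring carbon would also give steps that differ between the two cores. Going by these compounds, whether a third core would follow either pair also remains open.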